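The compounds below may be only part of what the source reports. "The series", "measured", "known", "first", "only" and "open" are said of these compounds alone.

Measured in a functional assay on MCF7 cells (Homo sapiens) for cytotoxicity, with a stated time of 72 h; on this read-out higher numbers stand for weaker inhibition and lower numbers for stronger inhibition:
- Compound 1 `Cc1cccc(-c2nn3c(c2-c2ccncc2)C(CO)C(C)(C)C3)n1`: > 100000 nM (a limit)
- Compound 2 `Cc1cccc(-c2nn3c(c2-c2ccncc2)CC(C)(C)C3)n1`: > 100000 nM (a limit)
- Compound 3 `Cc1cccc(-c2nn3c(c2-c2ccncc2)C(C)C(C)(C)C3)n1`: > 100000 nM (a limit)

Compound 3 gives > 100000 nM, which is a limit and not a number. The series as a whole shows (the limit of > 100000 nM in this assay, at which 3 of the 3 values shown sit), so compound 3 has no readable rank among the three.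

The next change leads to compound 4 `COCC1c2c(-c3ccncc3)c(-c3cccc(C)n3)nn2CC1(C)C` and is methoxy in place of hydrogen on a saturated chain carbon bound to a saturated ring carbon. It puts methoxy in place of hydrogen on a saturated chain carbon bound to a saturated ring carbon, which also reads as methyl to methoxymethyl.

The closest measured change at that place is a step that the two limits leave unreadable from compound 1 to compound 3. Less direct are a step that the two limits leave unreadable from compound 2 to compound 3 and a step that the two limits leave unreadable from compound 1 to compound 2. None of these gives a size or a direction, so no step beyond the scatter is expected in this assay. The expected outcome is a number no higher from compound 3 to compound 4 (the limit leaves the size open). For compound 4 the estimate is 100000 nM, with an expected range of 40000 nM to 200000 nM.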

Compound 4, half-maximal inhibitory concentration: > 100000 nM
Compound 4 gave a limit, no number; the forecaster's own chance of this, stated with the estimate: 85%; the middle value lies on the limit itself.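

Compound 4 adds no readable step to compound 1, compound 2 or compound 3, since all four stop at a limit: the limit of > 100000 nM in this assay, at which 4 of the 4 values shown sit.

The compounds shown leave open whether any of these changes shifts the value at all, in either direction or by any size.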